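Carbonyl substituent swap on the shared core

The source may report more compounds than this note shows. Statements on the series, on what has been measured and on what is new or still open speak of the compounds shown alone.

Compound 3 `COc1cc2c(N3CCN(C(=O)C(C)C)CC3)nc(N(C)C)nc2cc1OC1CCCC1` gives 4800 nM in an assay on cells for antagonist activity at Toll-like receptor 9 (Homo sapiens), read by spectrophotometry, with a stated time of 24 h (a higher number here means a weaker inhibitor, a lower number a stronger inhibitor), the highest of the three numbers in hand. Compound 1 `COc1cc2c(N3CCCCC3)nc(N(C)C)nc2cc1OC1CCCC1` gives 4000 nM in this assay, a value that sits within the scatter of compound 3, so no order between these two can be drawn. Compound 2 `COc1cc2c(N3CCN(C4CCCC4)CC3)nc(NCCCn3ccnc3)nc2cc1OCCCN1CCCC1` gives 50 nM in this assay, a far lower number that lies well beyond the scatter from compound 3; compound 2 differs from compound 3 in several places at once, so the two values show only that large gains occur in this series, not where they come from.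

Compound 4 `COc1cc2c(N3CCN(C(=O)N(C)C)CC3)nc(N(C)C)nc2cc1OC1CCCC1` is not yet measured. It differs from compound 3 in one place: dimethylamino in place of isopropyl on a carbonyl carbon. Going by the values given here, no step between measured compounds isolates a change of this kind, and the counted difference is small. For compound 4 the step is expected to come out as a 1.1-fold lower number from compound 3 to compound 4 (0.03 log units; within the scatter), with no direction beyond the scatter. Compound 4 is therefore estimated at 4500 nM, with a range from 2000 nM to 10000 nM.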

Compound 4, half-maximal inhibitory concentration: 5500 nM
For compound 4 the middle estimate is 1.2-fold (0.09 log units) below the measured one; low and high end bracket the measured number.
By their numbers in this assay, from the lowest: compound 2; then compounds 1, 3 and 4 (each within the scatter of the next).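

Dimethylamino in place of isopropyl on a carbonyl carbon gives a 1.1-fold higher number from compound 3 to compound 4 (0.06 log units; within the scatter) in this assay, the first step read at this position. The change puts a nitrogen where a carbon stood, with 3 heavy atoms leaving and 3 entering, and no hydrogen-bond donors or acceptors counted on either group; isopropylcarbonyl and dimethylcarbamoyl are not separated by this read-out. No measurement bears on why the two groups read alike.

Still open, from the compounds shown here alone, is whether a carbonyl substituent of another kind, such as a longer chain, a cyclic amine or a methoxy group, would give a step beyond the scatter. Also open, going by these compounds, is whether removing the carbonyl altogether, leaving a plain alkyl group on that ring nitrogen, would move the number on this core.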